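A Methyl on Nitrogen Where Hydrogen Sat Before

A few compounds are considered here, and "the series" means these few. Any claim that something is new, unique, unknown or untested is made for them only; others in the source may bear on it.

Measured compounds:
compound 1, `COc1ccccc1/C=c1/[nH]c(=O)/c(=C\c2ccccc2OC)[nH]c1=O`: "not active" (no number reported)
compound 2, `C=CCn1c(=O)/c(=C\c2cccc(Br)c2)[nH]c(=O)/c1=C\c1ccccc1OC`: 2400 nM
compound 3, `C=CCn1c(=O)/c(=C\c2ccccc2F)[nH]c(=O)/c1=C\c1ccccc1OC`: 5600 nM

In a functional assay on K562 cells (Homo sapiens) for cytotoxicity, read by CCK-8 assay, with a stated time of 72 h (on this read-out higher numbers stand for weaker inhibition and lower numbers for stronger inhibition), compound 1 is reported as "not active" (no number reported), so no single number stands for it. Compound 2 gives 2400 nM and compound 3 gives 5600 nM. Among the compounds with values here, the only single-change step among the measured compounds, a 2.3-fold higher number from compound 2 to compound 3 (0.37 log units; beyond the scatter), concerns an aryl exchange and does not touch a ring nitrogen. Compound 4, `COc1ccccc1/C=c1/[nH]c(=O)/c(=C\c2ccccc2OC)n(C)c1=O`, differs from compound 1 by methyl in place of hydrogen on an aromatic nitrogen. Within the data shown here, no measured step changes the substituent on that nitrogen, and compounds 2 and 3 differ from compound 1 in more than one place, so no step connects them to it. For compound 4 the number in this assay is therefore only roughly expected, estimated at 10000 nM, within 3000 nM to 40000 nM, with a real chance of no number at all.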

Compound 4, half-maximal inhibitory concentration: 2200 nM
Beside the measured number, compound 4's estimate is 4.5-fold (0.66 log units) above it; measured number outside the range, below it.
By their numbers in this assay, from the lowest: compounds 4 and 2 (each within the scatter of the next); then compound 3.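

Within the data shown here, compound 1 stands as [ "not active" (no number reported) ], so no step from compound 1 to compound 4 can be read. Going by these compounds, how much methyl in place of hydrogen on that aromatic nitrogen shifts the number stays open. Nothing shown accounts for the value of compound 4.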